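Replacing a methylsulfanyl group on the amide side chain

The source may hold more compounds than are shown below. What is called first, only, known or untested is meant among the compounds shown, and "the series" means these compounds.

Of the compounds shown here, three sharing one core have been measured in a physicochemical assay for solubility, read by HPLC; on this read-out lower numbers stand for lower solubility and higher numbers for higher solubility. Compound 1 `CSCC(=O)N1CCN(c2nc(=O)c3cc(C(F)(F)F)cc([N+](=O)[O-])c3s2)CC1` gives 15.2 ug/mL in this assay, the lowest of the three numbers. Compound 2 `CCC(C)C(=O)N1CCN(c2nc(=O)c3cc(C(F)(F)F)cc([N+](=O)[O-])c3s2)CC1` gives 104 ug/mL, and compound 3 `CC(C)CC(=O)N1CCN(c2nc(=O)c3cc(C(F)(F)F)cc([N+](=O)[O-])c3s2)CC1` gives 66.3 ug/mL. Compound 1 thus stands below both, with a 6.8-fold higher number from compound 1 to compound 2 (0.84 log units; beyond the scatter) and a 4.4-fold higher number from compound 1 to compound 3 (0.64 log units; beyond the scatter); the two alkyl analogues themselves differ only by a 1.6-fold lower number from compound 2 to compound 3 (0.20 log units; within the scatter).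

Compound 4 `CCC(=O)N1CCN(c2nc(=O)c3cc(C(F)(F)F)cc([N+](=O)[O-])c3s2)CC1` has not yet been measured. It differs from compound 1 in that (methyl in place of methylsulfanyl on a saturated chain carbon bound to a carbonyl carbon). Among the compounds with values here, the steps that bear on this change are those from compound 1 to the two alkyl amides, both of which remove the methylsulfanyl part and both of which gave clearly higher numbers. The group entering in compound 4 is the smallest of the three alkyl groups. The step is therefore expected to go upward, beyond the scatter, roughly as a 3.9-fold higher number from compound 1 to compound 4 (0.60 log units; beyond the scatter). Compound 4 is accordingly estimated to give about 60 ug/mL in this assay, within a range of 25 ug/mL to 150 ug/mL.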

Compound 4, solubility: 3.29 ug/mL
Beside the measured number, compound 4's estimate is 18-fold (1.26 log units) above it; measured number outside the range, below it.
By their numbers in this assay, from the lowest: compound 4; then compound 1; then compounds 3 and 2 (each within the scatter of the next).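

In this assay the loss of the methylsulfanyl group does not by itself raise the number: with methyl in its place there is a 4.6-fold lower number from compound 1 to compound 4 (0.66 log units; beyond the scatter) on this saturated chain carbon bound to a carbonyl carbon, so the direction of the change depends on the group that enters. The fall is large against the two larger alkyl amides (a 20-fold lower number from compound 3 to compound 4 (1.30 log units; beyond the scatter)) and (a 32-fold lower number from compound 2 to compound 4 (1.50 log units; beyond the scatter)), which places compound 4 lowest of the four and shows that alkyl groups at this position do not behave alike. The data shown offer nothing that accounts for so large a gap between these close analogues.

From the compounds shown here alone, it remains open whether a longer straight chain such as butanoyl stays as low as compound 4 or moves toward compound 2 and compound 3. Going by these compounds, it is also open where a methoxy group in place of methylsulfanyl would fall.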